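Hydroxy for Methoxy on a Bisaryl Pyrazole Scaffold

The source may report more compounds than this note shows. Statements on the series, on what has been measured and on what is new or still open speak of the compounds shown alone.

Measured compounds:
compound 1, `Cc1cc(O)cc(-c2nn(CC#N)cc2-c2ccnc(-c3ccc(Oc4ccccc4)cc3)c2)c1`: 7370 nM
compound 2, `COc1cc(C)cc(-c2nn(CC#N)cc2-c2ccnc(-c3ccc(N(C)C)cc3)c2)c1`: > 100000 nM

Of the compounds shown here, two have so far been tested in a functional assay on PC-3 cells (Homo sapiens) for inhibition, read by sulforhodamine B assay, with a stated time of 48 h; on this read-out lower numbers stand for stronger inhibition of growth and higher numbers for weaker inhibition of growth. Compound 1 gives 7370 nM in this assay. For compound 2 this assay reports no number, only a limit, > 100000 nM. Compound 2 therefore stands at the limit of > 100000 nM in this assay, at which 1 of the 2 values shown sits, the weaker end of what has been seen here. Among the measured compounds shown here, compound 1 and compound 2 differ in more than one place, so their two values show no single step.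

Compound 3, `Cc1cc(O)cc(-c2nn(CC#N)cc2-c2ccnc(-c3ccc(N(C)C)cc3)c2)c1`, has not yet been measured. It differs from compound 2 in one place: hydrogen in place of methyl on an oxygen on an aromatic ring. For the measured compounds named here, no measured pair isolates this change, so its size cannot be read from the data. The step from compound 2 to compound 3 is expected to run toward stronger inhibition, an at least 2.5-fold lower number from compound 2 to compound 3 (0.39 log units; beyond the scatter), though with wide uncertainty. Compound 3 is expected to give about 40000 nM in this assay, somewhere between 8000 nM and 150000 nM.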

Compound 3, concentration for total growth inhibition: 47200 nM
For compound 3 the middle estimate is 1.2-fold (0.07 log units) below the measured one; measured number inside the range.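

With dimethylamino held fixed, hydroxy in place of methoxy on the aromatic ring gives an at least 2.1-fold lower number from compound 2 to compound 3 (0.32 log units; beyond the scatter), which shows that this one change moves the read-out toward stronger inhibition of growth. Compound 2 has only a limit in this assay, so this step is a bound and not a measured size: the limit of > 100000 nM in this assay, at which 1 of the 3 values shown sits.

With hydroxy held fixed, dimethylamino in place of phenoxy gives a 6.4-fold higher number from compound 1 to compound 3 (0.81 log units; beyond the scatter), so the phenoxy compound remains the stronger of this pair and the change at that other place also registers beyond the scatter.

As far as these compounds go, how large the methoxy to hydroxy step really is remains open, as does whether it would carry over to the phenoxy series. Whether an amine or an ethoxy group in place of the hydroxy would keep, lose or improve the inhibition of growth is also left open.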